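A Smaller Aromatic Ring on the Shared Core

A few compounds are considered here, and "the series" means these few. Any claim that something is new, unique, unknown or untested is made for them only; others in the source may bear on it.

Three measured compounds share one core and differ only in the aromatic group attached to it. Compound 1 `COc1ccc(-c2nc3cccc(-c4cc(OC)c(OC)c(OC)c4)c3o2)cc1` carries a methoxy-substituted phenyl there, compound 2 `COc1cc(-c2cccc3nc(-c4ccc(Cl)cc4)oc23)cc(OC)c1OC` a 4-chlorophenyl, and compound 3 `COc1ccc(-c2cccc3nc(-c4ccc5cc[nH]c5c4)oc23)c(OC)c1OC` a larger fused aromatic group.

In a functional assay on MCF7 cells (Homo sapiens) for antiproliferative activity, read by MTT assay, with a stated time of 48 h (on this read-out lower numbers stand for stronger inhibition and higher numbers for weaker inhibition), compound 1 reaches only the limit of the method, > 25000 nM. In this assay compound 2 likewise gives only a limit, > 25000 nM. Compound 3 also stops at a limit in this assay, > 25000 nM. Among the compounds with values here, the one step between compounds differing in a single place, a step that the two limits leave unreadable from compound 1 to compound 2, cannot be sized because of the limit of > 25000 nM in this assay, at which 3 of the 3 values shown sit. So compound 2 stands with its two neighbours at the edge of what this assay can report, and none of the three gives a number to compare.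

Compound 4 `COc1cc(-c2cccc3nc(-c4cccs4)oc23)cc(OC)c1OC` differs from compound 2 as follows: thiophen-2-yl in place of 4-chlorophenyl on an aromatic carbon. Within the data shown here, no measured step offers a readable size on either side of this change, and every value shown is a limit. The plain expectation is therefore that compound 4 behaves like compound 2 and is estimated to give about 30000 nM in this assay, with a range from 8000 nM to 120000 nM. The expected step that the limit leaves unreadable from compound 2 to compound 4 is estimated to add nothing readable beyond the limit.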

Compound 4, half-maximal inhibitory concentration: > 25000 nM
Compound 4: no number, only a limit; the forecaster's own chance of this, stated with the estimate: 75%; the middle value lies beyond the limit too.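

Compound 4 also gives only a limit, so neither the step from compound 2 to compound 4 nor the step from compound 1 to compound 4 can be read: the limit of > 25000 nM in this assay, at which 4 of the 4 values shown sit.

The compounds shown leave open whether any aromatic group on the shared core gives a readable number in this assay, and how these groups compare with one another.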